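This account rests on a few compounds, and the source may have more. Where it says the series, first, only, none or still open, it means among the compounds named here.

Compound 1, `Cc1ccc(C(=O)CC2CC(=O)N(c3ccc(S(N)(=O)=O)cc3)C2=O)cc1`: 860 nM
Compound 2, `CC(=O)CC1CC(=O)N(c2ccccc2)C1=O`: 62400 nM
Compound 3, `CC1CCC(=O)C(C2CC(=O)N(Cc3ccccc3)C2=O)C1`: 56200 nM

Of the compounds shown here, three have been measured in an assay on cells (1-87 tumor cell line) for inhibition of Polyunsaturated fatty acid 5-lipoxygenase (Homo sapiens), with a stated time of 5 min; a lower number here means a stronger inhibitor, a higher number a weaker inhibitor. Compound 1 gives 860 nM. Compound 2 gives 62400 nM, the highest number of the three. Compound 3 gives 56200 nM, which lies within the scatter of compound 2, so the two cannot be told apart on these numbers. Compound 1 stands far lower than compound 2, well beyond the scatter, and is the only one of the three that reads as a clearly stronger inhibitor.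

Compound 4, `O=C1CCCC1C1CC(=O)N(c2ccccc2)C1=O`, has not been measured. It differs from compound 2 in one place: 2-oxocyclopentyl in place of 2-oxopropyl on a saturated ring carbon. The chain ketone of compound 2 is thus closed into a ring ketone, while the rest of the shared core and the phenyl on the ring nitrogen stay as they are. Going by the values given here, no pair of measured compounds shows this same change, so its size cannot be read off directly. Compound 3 also carries a ring ketone on the core, and its number sits within the scatter of compound 2, which gives no sign that a ring ketone in this position moves the number by much. The expectation is therefore a step from compound 2 to compound 4 of a 1.1-fold lower number from compound 2 to compound 4 (0.05 log units; within the scatter), no larger than the scatter in either direction. Compound 4 is estimated at 55000 nM, with a range from 15000 nM to 180000 nM.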

Compound 4, half-maximal inhibitory concentration: 98600 nM
Estimate against measurement, compound 4: 1.8-fold (0.25 log units) below; low and high end bracket the measured number.
By their numbers in this assay, from the lowest: compound 1; then compounds 3, 2 and 4 (each within the scatter of the next).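

In this assay, closing the 2-oxopropyl chain into a 2-oxocyclopentyl ring on this saturated ring carbon gives a 1.6-fold higher number from compound 2 to compound 4 (0.20 log units; within the scatter), so the two compounds cannot be told apart on these numbers. Going by these compounds alone, this is the first direct reading of this position with everything else held fixed: the ketone stays, the phenyl on the ring nitrogen stays, and going from 4 heavy atoms with no ring to 6 heavy atoms in a five-membered ring leaves no change that can be distinguished from the ordinary spread of repeated measurements. Nothing available offers an explanation for this result, and a single pair cannot show whether the same holds on any other core.

Compound 1, at 860 nM, differs from compound 2 in more than one place, so these compounds do not show which of its differences accounts for its much lower number. From the compounds shown here alone, it also remains open whether a group of another kind at this position, such as an amine, a carboxylic acid or a longer chain, would shift the number by more than this ring closure does.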